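A few compounds are considered here, and "the series" means these few. Any claim that something is new, unique, unknown or untested is made for them only; others in the source may bear on it.

Compound 1 `Cc1nc(-c2ccc(Cl)cc2)sc1C(=O)CSc1nc(-c2ccccc2)c(C#N)c(=O)[nH]1` and compound 2 `COc1ccc(-c2nc(C)c(C(=O)CSc3nc(-c4ccc(Cl)cc4)c(C#N)c(=O)[nH]3)s2)cc1` share the same core and were both tested in a functional assay on U-87MG ATCC cells for antiproliferative activity against U-87 MG (Homo sapiens), read by MTT assay, with a stated time of 48 h, tested at 10 uM; on this read-out lower numbers stand for a stronger effect and higher numbers for a weaker effect at the one concentration tested. In this assay compound 1 gives 83.1%, the lower of the two numbers shown. Compound 2 gives 92.7%, a reading within the scatter of that of compound 1, so the two cannot be ordered. Compound 3 `COc1ccc(-c2nc(SCC(=O)c3sc(-c4ccc(Cl)cc4)nc3C)[nH]c(=O)c2C#N)cc1` has not yet been measured. It differs from compound 1 in one place methoxy in place of hydrogen on an aromatic carbon and nowhere else. Among the measured compounds shown here, no measured pair differs by this change alone, and the two readings available both sit at the weak end of the range, so only a small step, if any, is expected in this assay. Compound 3 is therefore expected to give about 87% in this assay, with a range from 72% to 100%. The step of a number 3.9 percentage points higher from compound 1 to compound 3 (within the scatter) that this implies is expected to stay within the scatter.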

Compound 3, a percentage reported as activity, at one concentration (the size of the read-out at that concentration, not a potency): 88.3%
For compound 3 the middle estimate is 1.3 percentage points below the measured one; the measured number falls inside the stated range.
By their numbers in this assay, from the lowest: compounds 1, 3 and 2 (each within the scatter of the next).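

In this assay, the step for methoxy in place of hydrogen on an aromatic carbon, the change from phenyl to 4-methoxyphenyl, can now be read directly: a number 5.2 percentage points higher from compound 1 to compound 3 (within the scatter). The earlier compounds shown here offered no pair that differed by this change alone. At this place, para to a large group on the six-membered aromatic ring, the change therefore gives no step that can be told apart from the scatter at the one concentration tested, and the compounds shown offer no information on the reason for this.

Going by these compounds, what remains open is whether an amine, a carboxylic acid or a longer chain such as butoxy at the same place would give a step beyond the scatter. This single-concentration reading also leaves open whether methoxy and hydrogen would remain indistinguishable at other concentrations.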